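The source may report more compounds than this note shows. Statements on the series, on what has been measured and on what is new or still open speak of the compounds shown alone.

Measured compounds:
- compound 1 `Nc1n[nH]c2cc(-c3ccccn3)[nH]c(=O)c12`: 35%
- compound 2 `Cn1nc(N)c2c(=O)[nH]c(-c3ccccn3)cc21`: -4%
- compound 3 `Cc1cc2c(cn1)c(N)nn2C`: -2%

All three were run in an assay on isolated protein for inhibition of ribosomal protein S6 kinase alpha-5 (Homo sapiens), read by mobility shift assay, tested at 30 uM (a higher number here means more inhibition at the concentration tested (going by the name of the read-out), a lower number less inhibition), at a single concentration. Within the data shown here, the one counted step is a number 39 percentage points higher from compound 2 to compound 1 (beyond the scatter), which follows the change (hydrogen in place of methyl on an aromatic nitrogen). Compound 3 and compound 2 share no counted difference: the difference between the two cores is not broken down here, and compound 3 and compound 2 give numbers within the scatter of each other in this assay, so nothing can be said about order between them.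

Compound 4 `Cc1cc2[nH]nc(N)c2cn1` is compound 3 after the change (hydrogen in place of methyl on an aromatic nitrogen). The place lines for this change and for the change from compound 2 to compound 1 agree word for word, so it is the same change, now made on the core of compound 3 rather than that of compound 2. The step from compound 3 to compound 4 is expected at a number 20 percentage points higher from compound 3 to compound 4 (beyond the scatter), somewhat smaller than the earlier one because a number 39 percentage points higher from compound 2 to compound 1 (beyond the scatter) was seen on a different core and the same change need not carry over in full. Compound 4 is estimated at 18%, with a range from -5% to 42%.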

Compound 4, a percentage reported as inhibition, at one concentration (the size of the read-out at that concentration, not a potency): 13%
The estimate for compound 4 lay 5 percentage points above the measured number; low and high end bracket the measured number.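

Putting hydrogen in place of methyl on the aromatic nitrogen raises the number in this assay on the second core as well, the step being a number 15 percentage points higher from compound 3 to compound 4 (beyond the scatter). The change thus carries over from one core to the other in direction but not in size: the same change on two cores in this assay, a number 39 percentage points higher (beyond the scatter) from compound 2 to compound 1 and a number 15 percentage points higher (beyond the scatter) from compound 3 to compound 4, 24 percentage points apart, beyond the scatter of two such steps. Among these compounds, two cores do not show what sets the size of the step or whether the direction would hold on a further core, and readings at a single concentration give no potency for any compound.

Still open, from the compounds shown here alone, is how a longer chain such as ethyl or propyl on the same aromatic nitrogen would compare with methyl and hydrogen on either core. Also open, going by these compounds, is what a carboxylic acid in place of the amino group would do to the number in this assay, on the core of compound 1 as well as on that of compound 4.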